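The compounds below may be only part of what the source reports. "The series", "measured", "known", "first", "only" and "open" are said of these compounds alone.

Measured so far:
compound 1, `O=C(Nc1ccccc1O)c1c(NO)cc(-c2ccccc2)oc1=O` — 14000 nM
compound 2, `CCOc1ccccc1NC(=O)c1c(NCCO)cc(-c2ccccc2)oc1=O` — > 20000 nM

In an ADME assay on Huh-7 cells (Homo sapiens) for cytotoxicity, with a stated time of 3 days (a lower number here means that less compound is tolerated, a higher number that more compound is tolerated), compound 1 gives 14000 nM. For compound 2 only a limit is recorded in this assay, > 20000 nM, so its position on the scale is open-ended: it sits at the limit of > 20000 nM in this assay, at which 1 of the 2 values shown sits, and the two measured values cannot be ordered against each other beyond saying that compound 2 tolerates at least as much.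

Compound 3, `O=C(Nc1ccccc1O)c1c(NCCO)cc(-c2ccccc2)oc1=O`, is not yet measured. It differs from compound 2 by hydrogen in place of ethyl on an oxygen on an aromatic ring, in words: hydrogen in place of ethyl on an oxygen on an aromatic ring. Compound 3 therefore shares the 2-hydroxyphenyl amide with compound 1 and the hydroxyethylamino group with compound 2. Within the data shown here, no measured step between two compounds covers this change, so its size is not known from the data; the expectation is a step from compound 2 to compound 3 of an at least 1.1-fold lower number from compound 2 to compound 3 (0.04 log units; that floor lies within the scatter), which is not taken to be beyond the scatter. For compound 3 the estimate in this assay is 18000 nM, with a range from 8000 nM to 40000 nM.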

Compound 3, half-maximal cytotoxic concentration: > 20000 nM
Compound 3: a limit, no number; the forecaster's own chance of this, stated with the estimate: 40%; middle value at least 1.1-fold (0.04 log units) from the limit.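

In this assay compound 3 gives > 20000 nM, which is a limit and not a number. Ethoxy to hydroxy on the aromatic ring therefore does not bring the read-out to a measurable value, and the step between these two limits cannot be read: the limit of > 20000 nM in this assay, at which 2 of the 3 values shown sit.

With 2-hydroxyethyl in place of hydroxy on a nitrogen on an aromatic ring, the record gives an at least 1.4-fold higher number from compound 1 to compound 3 (0.15 log units; that floor lies within the scatter), so this change is not shown to go beyond the scatter.

Going by these compounds, how far compound 2 and compound 3 lie past the limit stays open, and so does any order between them. Also open, on these data alone, is whether a longer alkoxy chain on the oxygen, or a primary amine on the nitrogen, would give a number within the range of this assay.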